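Urea to amide exchange on the shared core

This account rests on a few compounds, and the source may have more. Where it says the series, first, only, none or still open, it means among the compounds named here.

Compound 2 `COc1cc(Cl)cc(-c2nn(-c3cccc(NC(=O)Nc4ccc(Cl)c(C(F)(F)F)c4)c3)cc2-c2ccncc2)c1` stands second highest of the three numbers in a functional assay on RPMI-8226 cells (Homo sapiens) for inhibition, read by sulforhodamine B assay, with a stated time of 48 h, tested at 1 uM (on this read-out higher numbers stand for a weaker effect at the one concentration tested and lower numbers for a stronger effect), giving 17%. Within the data shown here, compound 1 `O=C(Nc1cccc(-n2cc(-c3ccncc3)c(-c3cc(O)cc(Cl)c3)n2)c1)Nc1ccc(Cl)c(C(F)(F)F)c1` gives 88% in this assay, and the only single-point step recorded, a number 71 percentage points lower from compound 1 to compound 2 (beyond the scatter), comes from methyl in place of hydrogen on an oxygen on an aromatic ring. Among the measured compounds shown here, compound 3 `COc1cc(Cl)cc(-c2nn(-c3cccc(NC(=O)Nc4cc(C(F)(F)F)cc(C(F)(F)F)c4)c3)cc2-c2ccncc2)c1` gives -12% in this assay; no single step is recorded between compound 3 and compound 2, so only the two values stand side by side.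

For the measured compounds named here, compound 4 `COc1cc(Cl)cc(-c2nn(-c3cccc(NC(=O)c4cccc(C(F)(F)F)c4)c3)cc2-c2ccncc2)c1` is the next compound for this assay. 3-(trifluoromethyl)phenyl in place of (4-chloro-3-(trifluoromethyl)phenyl)amino on a carbonyl carbon No measured step touches this part of the molecule: the one recorded step concerns the oxygen on the aromatic ring, and the pair of compound 2 and compound 3 only shows two numbers beyond the scatter of each other. Replacing (4-chloro-3-(trifluoromethyl)phenyl)amino by 3-(trifluoromethyl)phenyl on the carbonyl carbon is a larger departure than anything measured, so the expectation is wide. In this assay compound 4 is expected to come in higher, a step of a number 38 percentage points higher from compound 2 to compound 4 (beyond the scatter), at an estimated 55% with a range from 15% to 95%.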

Compound 4, a percentage reported as activity, at one concentration (the size of the read-out at that concentration, not a potency): 79%
Beside the measured number, compound 4's estimate is 24 percentage points below it; the range from low to high includes it.
By their numbers in this assay, from the lowest: compound 3; then compound 2; then compounds 4 and 1 (each within the scatter of the next).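

In this assay, the group on the carbonyl carbon proves to be a second sensitive point of the series: a number 62 percentage points higher from compound 2 to compound 4 (beyond the scatter), with a weaker effect at the one concentration tested. Among these compounds, until now, the only recorded step concerned the oxygen on the aromatic ring, so this is the first single-place change to show a large effect at the carbonyl carbon. The change removes the amino nitrogen, with its hydrogen-bond donor, and the chlorine together, so the step belongs to the whole exchange and not to either feature alone.

The compounds shown change these two features only together. (3-(Trifluoromethyl)phenyl)amino or 4-chloro-3-(trifluoromethyl)phenyl on the carbonyl carbon would separate the two.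

No measurement available here explains the step.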